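Buffer stability of compound 1 and an ester variant

The compounds below may be only part of what the source reports. "The series", "measured", "known", "first", "only" and "open" are said of these compounds alone.

Compound 1 `C[C@@H](O)[C@H]1C(=O)N2C(C(=O)OCOC(=O)C(C)(C)C)=C(S[C@@H]3CN[C@H](C(=O)Nc4cccc(C(=O)O)c4)C3)[C@H](C)[C@H]12` was run in a physicochemical assay for metabolic stability, read by LC-MS, in phosphate buffer, with a stated time of 3 h, at pH 7.4, tested at 50 uM; a higher number here means that more of the compound is left, a lower number that less of the compound is left. The result for compound 1 is a limit of the assay, > 95%. Compound 2 `CCOC(=O)C1=C(S[C@@H]2CN[C@H](C(=O)Nc3cccc(C(=O)OCC)c3)C2)[C@H](C)[C@@H]2[C@@H]([C@@H](C)OC(C)=O)C(=O)N12` in this assay likewise returns a limit, > 95%. Compound 3 `C[C@@H](O)[C@H]1C(=O)N2C3=C(S[C@@H]4CN[C@@H](C4)C(=O)Nc4cccc(c4)C(=O)OC/C=C\COC3=O)[C@H](C)[C@H]12` in this assay also comes back as a limit, > 95%. The picture is therefore (the limit of > 95% in this assay, at which 3 of the 3 values shown sit); compound 1 stands there together with the other two, and no order among the three can be read from these values.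

Compound 4 `CC(C)OC(=O)OCOC(=O)C1=C(S[C@@H]2CN[C@H](C(=O)Nc3cccc(C(=O)O)c3)C2)[C@H](C)[C@@H]2[C@@H]([C@@H](C)O)C(=O)N12` has not been measured. It differs from compound 1 by isopropoxy in place of tert-butyl on a carbonyl carbon. Among the measured compounds shown here, no step between measured compounds bears on this change; the only guide is that every measured member of the series sits at the limit, as the limit of > 95% in this assay, at which 3 of the 3 values shown sit, records. The expected step is a number no higher from compound 1 to compound 4 (the limit leaves the size open), nothing beyond the scatter. Compound 4 is expected to give about 95%, with a range from 85% to 100%, and most likely to be reported again as a limit rather than a number.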

Compound 4, percent of the compound remaining: > 95%
Compound 4 was reported as a limit; the forecaster's own chance of this, stated with the estimate: 75%; the middle value sits exactly at the limit.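

Compound 1 and compound 4 both return only a limit, so no step between them can be read: the limit of > 95% in this assay, at which 4 of the 4 values shown sit.

The compounds shown leave open whether isopropoxy in place of tert-butyl on a carbonyl carbon changes the amount remaining in this assay, and how the series ranks.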